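The compounds below may be only part of what the source reports. "The series", "measured", "known", "first", "only" and "open" are said of these compounds alone.

Measured compounds:
compound 1 `CC(=O)N1CCC(Sc2c[nH]c3ccc(Cl)cc23)CC1` — 2.9 mg/kg
compound 2 `CC(=O)N1CCC(Sc2c[nH]c3ccc(Br)cc23)CC1` — 2.9 mg/kg
compound 3 `CCCC(=O)N1CCC(Sc2c[nH]c3ccc(Cl)cc23)CC1` — 8.9 mg/kg

In a functional assay on the whole organism with Mus musculus as the target, in the writhing test (on this read-out higher numbers stand for an effect only at larger amounts of compound and lower numbers for an effect already at smaller amounts), compound 2 gives 2.9 mg/kg, level with compound 1 and with it the lowest of the three numbers; no change at the digits printed from compound 1 to compound 2 (within the scatter). Compound 3 sits higher, at 8.9 mg/kg. Compound 4 `CCOC(=O)N1CCC(Sc2c[nH]c3ccc(Br)cc23)CC1` differs from compound 2 by ethoxy in place of methyl on a carbonyl carbon. Among the compounds with values here, the only measured step touching the group on the carbonyl carbon is a 3.1-fold higher number from compound 1 to compound 3 (0.49 log units; beyond the scatter), where a longer chain went with a modestly higher number. Compound 4 is therefore expected to show a modest rise in this assay, a 1.9-fold higher number from compound 2 to compound 4 (0.28 log units; within the scatter), though the step is not the same. The estimate for compound 4 is 5.5 mg/kg, with a range from 2.5 mg/kg to 12 mg/kg.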

Compound 4, dose for half-maximal effect: 6.3 mg/kg
Compound 4: middle estimate off by 1.1-fold (0.06 log units), on the low side; low and high end bracket the measured number.
By their numbers in this assay, from the lowest: compounds 1 and 2 (each within the scatter of the next); then compounds 4 and 3 (each within the scatter of the next).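

In this assay, acetyl to ethoxycarbonyl on the amide-type nitrogen gives a 2.2-fold higher number from compound 2 to compound 4 (0.34 log units; beyond the scatter) and so, with the bromo compounds, adds a second change on the carbonyl carbon that moves the number upward, alongside a 3.1-fold higher number from compound 1 to compound 3 (0.49 log units; beyond the scatter) with the chloro compounds. Here the entering group brings an oxygen rather than only a longer chain, and the number still rises modestly. Nothing available accounts for this rise.

Still open, as far as these compounds go, is what an amine or a phenyl ring on the carbonyl carbon would give. Whether ethoxy in place of methyl does the same with chloro on the shared core also stays unsettled.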